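Fluorine added to the 2,4-difluorophenyl compound 3

The compounds below may be only part of what the source reports. "The series", "measured", "known", "first", "only" and "open" are said of these compounds alone.

Measured in a functional assay on ECV-304 cells (Homo sapiens) for cytotoxicity (a higher number here means a weaker inhibitor, a lower number a stronger inhibitor), all values being limits:
- compound 1 `COc1cccc(/C=C2\SC(=S)N(NS(=O)(=O)c3ccccc3)C2=O)c1`: > 50000 nM
- compound 2 `O=C1/C(=C/c2ccccc2F)SC(=S)N1NS(=O)(=O)c1ccccc1`: > 50000 nM
- compound 3 `O=C1/C(=C/c2ccc(F)cc2F)SC(=S)N1NS(=O)(=O)c1ccccc1`: > 50000 nM

Compound 3 gives > 50000 nM, which is a limit and not a number. Going by the values given here, the whole series so far sits at the limit of > 50000 nM in this assay, at which 3 of the 3 values shown sit.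

Compound 4 `O=C1/C(=C/c2cc(F)c(F)cc2F)SC(=S)N1NS(=O)(=O)c1ccccc1` carries one further change, (fluoro in place of hydrogen on an aromatic carbon), which turns the 2,4-difluorophenyl into 2,4,5-trifluorophenyl.

The closest measured precedent is a step that the two limits leave unreadable from compound 2 to compound 3, also fluoro in place of hydrogen on an aromatic carbon. The replacements of the 3-methoxyphenyl, a step that the two limits leave unreadable from compound 1 to compound 2 and a step that the two limits leave unreadable from compound 1 to compound 3, give no size either. The data therefore offer no readable step to carry over and no direction, so no step beyond the scatter is expected in this assay. The estimated change is a number no higher from compound 3 to compound 4 (the limit leaves the size open). Another limit is the most likely report. Compound 4 is estimated at 50000 nM, with an expected range of 20000 nM to 100000 nM.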

Compound 4, half-maximal inhibitory concentration: > 50000 nM
Compound 4: only a limit was reported; the forecaster's own chance of this, stated with the estimate: 80%; the middle value lies on the limit itself.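

In this assay compound 4 gives > 50000 nM, a limit and not a number. Its steps from compound 1, compound 2 and compound 3 therefore cannot be read. Whether any change shown here moves the value in this assay stays open, as no compound shown gives a number: the limit of > 50000 nM in this assay, at which 4 of the 4 values shown sit.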